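Pyridin-4-yl on the amide after three limit readings

The source may report more compounds than this note shows. Statements on the series, on what has been measured and on what is new or still open speak of the compounds shown alone.

Working notes on the series in an ADME assay on MRC5 cells (Homo sapiens) for inhibition, with a stated time of 72 h; on this read-out lower numbers stand for an effect already at smaller amounts and higher numbers for an effect only at larger amounts of compound. Compound 1 (`COc1cccc(OC)c1C(=O)Nc1c[nH]nc1C(=O)NC1CCC1`) reads > 50000 nM as a limit of the assay. Compound 2 (`COc1cccc(OC)c1C(=O)Nc1c[nH]nc1C(=O)O`) reads > 50000 nM as a limit too. Compound 3 (`COc1cccc(OC)c1C(=O)Nc1c[nH]nc1C(=O)NCCCOC(C)C`) reads > 50000 nM as a limit as well, so it has no number of its own and shares its place with the other two (the limit of > 50000 nM in this assay, at which 3 of the 3 values shown sit).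

The next change leads to compound 4 (`COc1cccc(OC)c1C(=O)Nc1c[nH]nc1C(=O)Nc1ccncc1`), with pyridin-4-yl in place of 3-isopropoxypropyl on an amide-type nitrogen. The measured steps that bear on it are a step that the two limits leave unreadable from compound 1 to compound 3 at this same nitrogen, and a step that the two limits leave unreadable from compound 1 to compound 2 and a step that the two limits leave unreadable from compound 2 to compound 3 at the carbonyl carbon. None of them has a readable size, and no aromatic ring on this nitrogen has been measured. With no size to carry over, no step beyond the scatter is expected, and another limit reading is the likeliest outcome. The estimated change in this assay is a number no higher from compound 3 to compound 4 (the limit leaves the size open) as an expectation only. Compound 4 is expected at 50000 nM with a range from 20000 nM to 80000 nM as estimated here.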

Compound 4, half-maximal effective concentration: > 50000 nM
Compound 4 was reported as a limit; the forecaster's own chance of this, stated with the estimate: 85%; the middle value lies on the limit itself.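

Compound 4 is again a limit reading, so no step from compound 1, compound 2 or compound 3 to compound 4 can be read in this assay: the limit of > 50000 nM in this assay, at which 4 of the 4 values shown sit.
The compounds shown leave open whether any change on the amide-type nitrogen shifts the read-out in this assay at all.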